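Lengthening the acid chain on compound 2's ring nitrogen

A few compounds are considered here, and "the series" means these few. Any claim that something is new, unique, unknown or untested is made for them only; others in the source may bear on it.

Of the compounds shown here, three have been tested in a functional assay on CHO-K1 cells for antagonist activity at cysteinyl leukotriene receptor 1 (Homo sapiens), read by fluorescence and calcium flux, with stated times of 30 min and 1 h; a lower number here means a stronger inhibitor, a higher number a weaker inhibitor. Compound 1 `Cc1c(Cl)cccc1CCCCOc1ccc(C#Cc2cccc3c(CC(=O)O)c(C)n(CCCCC(=O)O)c23)cc1` gives 65 nM. Compound 2 `Cc1c(Cl)cccc1CCCCOc1ccc(C#Cc2cccc3c(CCCC(=O)O)c(C)n(CC(=O)O)c23)cc1` gives 0.22 nM, the lowest of the three numbers, and therefore the strongest inhibitor shown. Compound 3 `O=C(O)CCCn1cc(CC(=O)O)c2c(/C=C/c3ccc(OCCCCOc4ccccc4)cc3)cccc21` gives 12 nM, the nearest to compound 2 yet far beyond the usual scatter, while compound 1 lies furthest away.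

Compound 4 `Cc1c(Cl)cccc1CCCCOc1ccc(C#Cc2cccc3c(CCCC(=O)O)c(C)n(CCCCC(=O)O)c23)cc1` has not yet been measured. It differs from compound 2 in one place: 3-carboxypropyl in place of carboxy on a saturated chain carbon bound to an aromatic nitrogen. Put another way, the short acid arm on the ring nitrogen of compound 2 is stretched into a longer one, so that compound 4 carries two long acid chains. Compound 1 also carries the longer arm on its ring nitrogen. Its other chain differs as well, so the gap between compound 1 and compound 2 cannot be laid at the door of the nitrogen arm alone.

For the measured compounds named here, no single-change step is available, so the expectation rests on the general view that the lowest value in a small set is rarely matched once a chain is altered. A moderate weakening from compound 2 to compound 4 is expected, a 9.1-fold higher number from compound 2 to compound 4 (0.96 log units; beyond the scatter), beyond the scatter but far short of the gap to compound 1. Compound 4 is therefore estimated at 2 nM, within a range of 0.4 nM to 10 nM.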

Compound 4, half-maximal inhibitory concentration: 56 nM
Estimate against measurement, compound 4: 28-fold (1.45 log units) below; the measured number lies above the stated range.
By their numbers in this assay, from the lowest: compound 2; then compound 3; then compounds 4 and 1 (each within the scatter of the next).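

In this assay, for the compounds shown here, lengthening the acid arm on the ring nitrogen from carboxymethyl to 4-carboxybutyl gives a 250-fold higher number from compound 2 to compound 4 (2.41 log units; beyond the scatter), the first clean reading of this position, and it shows that this single change alone can cost a very large share of the potency. The other acid chain, on the saturated carbon bound to an aromatic carbon, behaves quite differently in the presence of the long nitrogen arm: its lengthening gives a 1.2-fold lower number from compound 1 to compound 4 (0.06 log units; within the scatter), so with that arm in place the two chain lengths shown cannot be told apart. Nothing measured here explains why the longer nitrogen arm weakens inhibition so sharply.

The compounds shown jump from the carboxymethyl arm straight to the 4-carboxybutyl arm on this core, so a 2-carboxyethyl or 3-carboxypropyl arm on that nitrogen would be needed to tell whether the loss sets in gradually or at one particular length. As far as these compounds go, it also remains open whether the length of the other chain matters when the short carboxymethyl arm is present, and whether an amide could stand in for the carboxylic acid on the nitrogen arm.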